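A few compounds are considered here, and "the series" means these few. Any claim that something is new, unique, unknown or untested is made for them only; others in the source may bear on it.

Compound 1 `CCC(C)n1ncn(-c2ccc(N3CCN(c4ccc(OC[C@@H]5CO[C@@](Cn6cnc(C)n6)(c6ccc(Cl)cc6Cl)O5)cc4)CC3)cc2)c1=O` was examined in a functional assay on HUVEC cells (Homo sapiens), read by scintillation counting and thymidine incorporation, with a stated time of 24 h (on this read-out lower numbers stand for stronger inhibition and higher numbers for weaker inhibition), where compound 1 gives 272 nM. Among the three compounds measured so far, that is the highest of the numbers shown, although the gap to compound 2 lies within the scatter. Compound 2 `CCc1nccn1C[C@@]1(c2ccc(Cl)cc2Cl)OC[C@@H](COc2ccc(N3CCN(c4ccc(-n5cnn(C(C)CC)c5=O)cc4)CC3)cc2)O1` gives 224 nM in this assay, and compound 3 `CCC(C)n1ncn(-c2ccc(N3CCN(c4ccc(OC[C@@H]5CO[C@@](Cn6cnc(C)c6)(c6ccc(Cl)cc6Cl)O5)cc4)CC3)cc2)c1=O` gives 102 nM. The three differ only in the small aromatic ring on a saturated chain carbon bound to a saturated ring carbon: a 1.2-fold lower number from compound 1 to compound 2 (0.08 log units; within the scatter), a 2.7-fold lower number from compound 1 to compound 3 (0.43 log units; beyond the scatter), and a 2.2-fold lower number from compound 2 to compound 3 (0.34 log units; beyond the scatter).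

Compound 4 `CCC(C)n1ncn(-c2ccc(N3CCN(c4ccc(OC[C@@H]5CO[C@@](Cn6nnnc6C)(c6ccc(Cl)cc6Cl)O5)cc4)CC3)cc2)c1=O` has not yet been measured. It differs from compound 1 at the same place: 5-methyl-1H-tetrazol-1-yl in place of 3-methyl-1H-1,2,4-triazol-1-yl on a saturated chain carbon bound to a saturated ring carbon. All three measured steps concern swaps of this ring, and none of them moved the number by more than a modest amount in either direction. A swap of one five-membered aromatic ring for another of the same size is therefore expected to leave the number near that of compound 1, with at most a modest change. This gives an expected step of a 1.1-fold lower number from compound 1 to compound 4 (0.04 log units; within the scatter). Compound 4 is thus estimated at 250 nM, with a range from 100 nM to 600 nM.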

Compound 4, half-maximal inhibitory concentration: 101 nM
The estimate for compound 4 lay 2.5-fold (0.39 log units) above the measured number; measured number inside the range.
By their numbers in this assay, from the lowest: compounds 4 and 3 (each within the scatter of the next); then compounds 2 and 1 (each within the scatter of the next).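

In this assay, going by these compounds alone, moving to 5-methyl-1H-tetrazol-1-yl on a saturated chain carbon bound to a saturated ring carbon gives a clear change (a 2.7-fold lower number from compound 1 to compound 4 (0.43 log units; beyond the scatter)), so compound 3 is no longer the only compound set apart from compound 1 by this ring. The tetrazole also separates from the ethyl-bearing imidazole (a 2.2-fold lower number from compound 2 to compound 4 (0.35 log units; beyond the scatter)) but not from the 4-methyl-1H-imidazol-1-yl ring (a 1.0-fold lower number from compound 3 to compound 4 (0.00 log units; within the scatter)), which places compounds 3 and 4 together, with compounds 1 and 2 as a second pair. The leaving and entering rings of the step from compound 1 are both five-membered and aromatic, each has 6 heavy atoms with its methyl group and neither has a net charge, so matching these counts is not enough to keep the number unchanged at this position.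

Nothing shown here explains why these rings separate in this way. As far as these compounds go, it also remains open whether an unsubstituted 1H-tetrazol-1-yl ring, a 1H-pyrazol-1-yl ring, or a non-aromatic group such as an amine or a carboxylic acid at the same place would stay level with compounds 3 and 4.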